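The source may hold more compounds than are shown below. What is called first, only, known or untested is meant among the compounds shown, and "the series" means these compounds.

Compound 1 `Cc1cc(=O)[nH]c(=O)n1C1O[C@H](C)[C@@H](O)[C@H]1O`: 9.5
Compound 2 `CCCc1cc(=O)[nH]c(=O)n1C1O[C@H](C)[C@@H](O)[C@H]1O`: 9.5
Compound 3 `O=c1cc(CO)n(C2O[C@H](CO)[C@@H](O)[C@H]2O)c(=O)[nH]1`: 9.8

In an ADME assay, compound 2 gives 9.5, level with compound 1, while compound 3, the furthest from it, gives 9.8, a gap still within the scatter. The next compound to be measured is compound 4 `CCc1cc(=O)[nH]c(=O)n1C1O[C@H](C)[C@@H](O)[C@H]1O`. It differs from compound 2 by a single change, hydrogen in place of methyl on a saturated chain carbon, two bonds along the chain from an aromatic carbon, so that propyl becomes ethyl.

Among the compounds with values here, one measured step bears on this: no change at the digits printed from compound 1 to compound 2 (within the scatter). That step passes from methyl to propyl, and the ethyl of compound 4 is a stage on the same path. With no movement seen over that whole path, no shift beyond the scatter is expected in this assay. The expected size of the change is no change at the digits printed from compound 2 to compound 4 (within the scatter). For compound 4 the estimate is 9.5, with an expected range of 9.2 to 9.8.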

Compound 4, acid dissociation constant: 9.5
Compound 4: middle estimate and measured number agree at the digits printed; measured number inside the range.
By their numbers in this assay, from the lowest: compounds 1, 2, 4 and 3 (each within the scatter of the next).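

In this assay, shortening propyl to ethyl gives no change at the digits printed from compound 2 to compound 4 (within the scatter), and placing methyl on the chain carbon bound to an aromatic carbon gives no change at the digits printed from compound 1 to compound 4 (within the scatter). Methyl, ethyl and propyl at this position on the shared core therefore all read alike within the scatter, and the middle member of the series now confirms what had previously rested on a single step between its two ends. No supporting measurement is available to say why the number stays level.

From the compounds shown here alone, whether a longer chain, an amine or a carboxylic acid at this position would also leave the number level remains open. Compound 3 differs from these compounds in more than one place, so it cannot settle that question.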